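The source may hold more compounds than are shown below. What is called first, only, known or untested is meant among the compounds shown, and "the series" means these compounds.

The three measured compounds share one core. Compound 1 `CCc1ccc(Nc2nccc(-c3ccncc3)n2)cc1`, compound 2 `CCOC(=O)c1cccc(Nc2nccc(-c3ccccn3)n2)c1` and compound 3 `Cc1cccc(Nc2nccc(-c3cc(C)oc3C)n2)c1` have each been tested in a functional assay for inhibition, with Homo sapiens as the target; a higher number here means a weaker inhibitor, a lower number a stronger inhibitor. In this assay compound 1 gives 7700 nM. Compound 2 gives 3000 nM, the lowest of the three numbers. Compound 3 gives 28500 nM, the highest. Compound 2 therefore stands at the bottom of the range; compound 1 is nearest to it, and the gap between the two lies beyond the usual scatter, while compound 3 lies furthest from it, again beyond the scatter.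

Compound 4 `CN(C)c1cccc(Nc2nccc(-c3ccccn3)n2)c1` has not yet been measured. It differs from compound 2 in a single place: dimethylamino in place of ethoxycarbonyl on an aromatic carbon. Going by the values given here, no pair of measured compounds differs by this same change, so no measured step shows what size of shift to expect, and compound 1 and compound 3 differ from compound 2 in other ways and give no parallel. The step expected is a 2.0-fold higher number from compound 2 to compound 4 (0.30 log units; within the scatter), a moderate move upward, toward a weaker inhibitor, though a shift in either direction would not surprise. For compound 4 the estimate in this assay is 6000 nM, with a range from 1500 nM to 24000 nM.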

Compound 4, half-maximal inhibitory concentration: 400 nM
Compound 4: the middle estimate sits 15-fold (1.18 log units) above what was measured; measured number below the stated range.
By their numbers in this assay, from the lowest: compound 4; then compound 2; then compound 1; then compound 3.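

Replacing ethoxycarbonyl with dimethylamino on this aromatic carbon, meta to a large group, gives a 7.5-fold lower number from compound 2 to compound 4 (0.88 log units; beyond the scatter) in this assay, a step beyond the scatter toward a stronger inhibitor. Going by these compounds alone, this is the first measured step in which only one place changes, and it shows that this position responds to the group it carries and that ethoxycarbonyl is not needed there, since a group with a nitrogen in place of the two oxygens, and with no double bond outside aromatic rings, gives the lower number. Nothing at hand accounts for the size or the direction of this step, so the result records what happens at this position and not the reason for it.

The compounds shown leave open whether a primary amine, a diethylamino group, a methoxy group or a carboxylic acid on the same carbon would give a lower or a higher number than dimethylamino does. They also leave open whether dimethylamino would bring a similar step on the differently substituted cores of compound 1 and compound 3, since this change has been seen only once, from the ester of compound 2.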